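Removing a second methoxy group from compound 3

The source may hold more compounds than are shown below. What is called first, only, known or untested is meant among the compounds shown, and "the series" means these compounds.

Of the compounds shown here, three sharing one core have been measured in a functional assay on OVCAR-3 cells (Homo sapiens) for inhibition, read by sulforhodamine B assay, with a stated time of 48 h; on this read-out lower numbers stand for stronger inhibition of growth and higher numbers for weaker inhibition of growth. Compound 1 `CCOC(=O)[C@H](CCC(=O)O)NC(=O)c1ccc(Sc2nc3cc(N)cc(N)c3nc2-c2ccccc2)cc1` gives 12300 nM. Compound 2 `COc1cc(CNc2nc3cc(N)cc(N)c3nc2-c2ccccc2)cc(OC)c1OC` gives 1150 nM, and compound 3 `COc1ccc(CNc2nc3cc(N)cc(N)c3nc2-c2ccccc2)cc1OC` gives 1320 nM. Among these three numbers compound 3 stands second highest; its nearest neighbour is compound 2, within the scatter, and its furthest is compound 1, beyond the scatter. Among the measured compounds shown here, the one step measured between neighbours, a 1.1-fold higher number from compound 2 to compound 3 (0.06 log units; within the scatter), came from a hydrogen in place of methoxy on an aromatic carbon and left the growth inhibition essentially unchanged.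

Compound 4 `COc1ccc(CNc2nc3cc(N)cc(N)c3nc2-c2ccccc2)cc1` has not yet been measured. It differs from compound 3 in this way: hydrogen in place of methoxy on an aromatic carbon. The same kind of change has already been made once, from compound 2 to compound 3, and that step stayed within the scatter. For the measured compounds named here, with only this one precedent, and the change this time sitting ortho to a methoxy group and meta to a large group, a step no larger than the scatter is expected in this assay, with a slight lean toward a higher number. For compound 4 the step is estimated as a 1.2-fold higher number from compound 3 to compound 4 (0.08 log units; within the scatter). Compound 4 is therefore expected to give about 1600 nM, with a range from 700 nM to 3600 nM.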

Compound 4, concentration for 50% growth inhibition: 2240 nM
The estimate for compound 4 lay 1.4-fold (0.15 log units) below the measured number, within the range that was stated.
By their numbers in this assay, from the lowest: compounds 2, 3 and 4 (each within the scatter of the next); then compound 1.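

In this assay the change from 3,4-dimethoxyphenyl to 4-methoxyphenyl gives a 1.7-fold higher number from compound 3 to compound 4 (0.23 log units; within the scatter) and so stays within the scatter. Hydrogen in place of methoxy has now been read twice in this series: the earlier case was a 1.1-fold higher number from compound 2 to compound 3 (0.06 log units; within the scatter) and the new one, ortho to a methoxy group and meta to a large group, shows that this second position also takes the change without a step beyond the scatter. No measurement at hand speaks to what lies behind the size of either step.

The compounds shown leave open whether the last methoxy group on this ring can also give way to hydrogen, and whether an amine, a carboxylic acid or a longer chain such as ethoxy in its place would bring a step beyond the scatter. They also leave open which feature sets compound 1 at 12300 nM apart, since it differs from the other compounds in more than one place and no single change can be read from it.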